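A Fluoro Step on a Scaffold Without Measurable Toxicity

A few compounds are considered here, and "the series" means these few. Any claim that something is new, unique, unknown or untested is made for them only; others in the source may bear on it.

compound 1, `Cn1c(-c2ccccc2)cnc1NC(=O)c1ccc(F)cc1`, > 100000 nM
compound 2, `Cn1c(-c2ccccc2)cnc1NC(=O)c1ccccc1`, > 100000 nM
compound 3, `Cc1ccc(C(=O)Nc2ncc(-c3ccccc3)n2C)cc1`, > 50000 nM

In a toxicity assay on THP-1 cells (Homo sapiens) for inhibition (a lower number here means that less compound is tolerated, a higher number that more compound is tolerated), compound 1 gives > 100000 nM, which is a limit of the assay and not a number. Compound 2 likewise stands at a limit, > 100000 nM. Compound 3 also stands at a limit, > 50000 nM. Compound 4, `Cn1c(-c2cccc(F)c2)cnc1NC(=O)c1ccc(F)cc1`, differs from compound 1 by fluoro in place of hydrogen on an aromatic carbon. The measured steps a step that the two limits leave unreadable from compound 1 to compound 2, a step that the two limits leave unreadable from compound 1 to compound 3 and a step that the two limits leave unreadable from compound 2 to compound 3 cannot be sized because the limit of > 100000 nM in this assay, at which 2 of the 3 values shown sit, and the limit of > 50000 nM in this assay, at which 1 of the 3 values shown sits, cap every value shown. No readable step therefore bears on the change. Compound 4 is expected to show no step beyond the scatter, a number no higher from compound 1 to compound 4 (the limit leaves the size open). Compound 4 is estimated at 100000 nM, between 50000 nM and 200000 nM.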

Compound 4, half-maximal cytotoxic concentration: 58000 nM
Estimate against measurement, compound 4: 1.7-fold (0.24 log units) above, within the range that was stated.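

Compound 4 is the only compound shown whose value in this assay is a number and not a limit. Going by these compounds alone, the change from phenyl to 3-fluorophenyl on the core of compound 1 comes with an at least 1.7-fold lower number from compound 1 to compound 4 (0.23 log units; that floor lies within the scatter), so this position is the first to give a readable step, though not one that can be told from scatter. Its true size stays open because compound 1 stands at a limit: the limit of > 100000 nM in this assay, at which 2 of the 4 values shown sit.

The compounds shown leave open whether chloro, an amine or a carboxylic acid at this same place would lower the number beyond the scatter. They also leave open whether the same change on compound 2 would give a similar step.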